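Thiophene in Place of Chlorophenyl on the Sulfonyl Group

A few compounds are considered here, and "the series" means these few. Any claim that something is new, unique, unknown or untested is made for them only; others in the source may bear on it.

Three compounds have been measured in a functional assay on HeLa cells for antagonist activity at 5-hydroxytryptamine receptor 6 (Homo sapiens); on this read-out lower numbers stand for smaller maximal responses and higher numbers for larger maximal responses:

Compound 1 `CCn1nc(S(=O)(=O)c2cccc3ccccc23)c2cc(N3CCN(C)CC3)ccc21` gives 100%
Compound 2 `CN1CCN(c2ccc3[nH]nc(S(=O)(=O)c4ccc(F)cc4)c3c2)CC1` gives 98%
Compound 3 `CN1CCN(c2ccc3[nH]nc(S(=O)(=O)c4ccc(Cl)cc4)c3c2)CC1` gives 100%

Compound 3 stands level with compound 1 at the digits given, and compound 2 lies within the usual scatter of both. Among the measured compounds shown here, the only single-point step among the measured compounds, a number 2 percentage points higher from compound 2 to compound 3 (within the scatter), arises from a chloro in place of fluoro on an aromatic carbon and changes nothing beyond the scatter.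

Compound 4 `CN1CCN(c2ccc3[nH]nc(S(=O)(=O)c4cccs4)c3c2)CC1` differs from compound 3 in one place: thiophen-2-yl in place of 4-chlorophenyl on a sulfonyl sulfur. For the measured compounds named here, this is a larger change than the halogen swap, since the whole aromatic ring on the sulfonyl sulfur is exchanged, and no measured pair shows a ring exchange of this kind. Going by the values given here, the only step that bears on it at all, a number 2 percentage points higher from compound 2 to compound 3 (within the scatter), shows that altering the aryl group on the sulfonyl sulfur left the maximal response essentially untouched, and all three measured compounds reach a near-complete response. Compound 4 is therefore expected to follow the same pattern, with a number 2 percentage points lower from compound 3 to compound 4 (within the scatter) as the estimated step, so that compound 4 is estimated to give 98%, within a range of 85% to 108%.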

Compound 4, largest response reached (reported as Imax), in percent of the reference or control that the assay uses: 96%
The estimate for compound 4 lay 2 percentage points above the measured number, within the range that was stated.
By their numbers in this assay, from the lowest: compounds 4, 2, 1 and 3 (each within the scatter of the next).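

In this assay, thiophen-2-yl on the sulfonyl sulfur gives a number 4 percentage points lower from compound 3 to compound 4 (within the scatter) when set against 4-chlorophenyl and a number 2 percentage points lower from compound 2 to compound 4 (within the scatter) when set against 4-fluorophenyl. The earlier compounds shown here showed only a halogen exchange on a phenyl ring that stayed in place, whereas these two pairs show that the whole aromatic ring can be exchanged, a six-membered carbon ring for a five-membered ring with a hetero atom, without a step beyond the scatter. No separate measurement is available that could explain this outcome.

The compounds shown leave open whether a group that is not an aromatic ring, such as cyclohexyl or methyl, would keep the read-out of this assay in the same range when placed on the sulfonyl sulfur. They also leave open what a basic amine or a carboxylic acid carried on the thiophen-2-yl group would do to that read-out, since every aryl group seen here bears at most a single halogen.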